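This account rests on a few compounds, and the source may have more. Where it says the series, first, only, none or still open, it means among the compounds named here.

Measured compounds:
- compound 1 `CCCCCCCOc1nc(N)nc2[nH]cnc12` — in an assay on HT-29 cells for inhibition of Methylated-DNA--protein-cysteine methyltransferase (Homo sapiens) (a lower number here means a stronger inhibitor, a higher number a weaker inhibitor), compound 1 gives > 100000 nM
- compound 2 `Nc1nc(OCCc2ccccc2)c2nc[nH]c2n1` — in this assay compound 2 gives 548000 nM
- compound 3 `CC1(C)OCC(COc2nc(N)nc3[nH]cnc23)O1` — in this assay compound 3 gives > 1000000 nM

Compound 1 stands at a limit of this assay, not at a number, so its place among the three can be told only loosely. Compound 3 likewise stands at a limit of this assay, the one described by the limit of > 1000000 nM in this assay, at which 1 of the 3 values shown sits. Only compound 2 gives a number, and the step from compound 1 to compound 2, a step that the limit leaves unreadable from compound 1 to compound 2, cannot be read in size because of the limit of > 100000 nM in this assay, at which 1 of the 3 values shown sits.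

Compound 4 `Nc1nc(OCC2=CCCC2)c2nc[nH]c2n1` differs from compound 1 in one place: cyclopent-1-en-1-yl in place of hexyl on a saturated chain carbon bound to an oxygen on an aromatic ring. Going by the values given here, the only measured step that bears on it is the one from compound 1 to compound 2, a change on the same chain, and that step is unreadable. Nothing measured therefore points to a direction or a size beyond the scatter. The expectation is that compound 4 stays in the weak range where compound 1 and compound 2 are found, with a fair chance that this assay again returns only a limit. Compound 4 is estimated at 300000 nM, between 100000 nM and 1000000 nM, which is expected to mean a step that the limit leaves unreadable from compound 1 to compound 4.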

Compound 4, half-maximal inhibitory concentration: 390 nM
The estimate for compound 4 lay 770-fold (2.89 log units) above the measured number; measured number outside the range, below it.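

Going by these compounds alone, the change brings an at least 250-fold lower number from compound 1 to compound 4 (2.40 log units; beyond the scatter) in this assay, which shows that this place on a saturated chain carbon bound to an oxygen on an aromatic ring, where the earlier compounds were all weak, can respond strongly to the group it carries. A ring on the chain is not enough by itself: compound 2, which has phenyl on its chain, gives 548000 nM, while compound 4, with cyclopent-1-en-1-yl, gives 390 nM. The size of the new step is only a bound, and the step to compound 2 cannot be read, because compound 1 stands at a limit and not at a number: the limit of > 100000 nM in this assay, at which 1 of the 4 values shown sits.

The compounds shown leave open which part of the change carries the step, whether the five-membered ring, its double bond or the smaller number of carbons, and they give no reason for the gain. A saturated cyclopentyl in the same place would separate the ring from the double bond, and a phenyl set directly on the same chain carbon would show whether an aromatic ring can do the same there.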